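Swapping a triazole for a benzamide on the benzylic arm

The source may hold more compounds than are shown below. What is called first, only, known or untested is meant among the compounds shown, and "the series" means these compounds.

Measured compounds and their values:
compound 1 `NS(=O)(=O)c1cc(-c2nnc(CN3CCN(c4ccc(F)cc4)CC3)o2)c(Cl)cc1SCc1ccccc1` 34000 nM
compound 2 `NC(=O)c1cn(Cc2nnc(-c3cc(S(N)(=O)=O)c(SCc4ccccc4)cc3Cl)o2)nn1` 72000 nM
compound 3 `COc1ccc(-c2cn(Cc3nnc(-c4cc(S(N)(=O)=O)c(SCc5ccccc5)cc4Cl)o3)nn2)cc1` 190000 nM

In a functional assay on HCT-116 cells (Homo sapiens) for cytotoxicity, read by MTT assay, with a stated time of 72 h (on this read-out higher numbers stand for weaker inhibition and lower numbers for stronger inhibition), compound 2 gives 72000 nM, the second highest of the three numbers. Its nearest neighbour is compound 1 with 34000 nM, a lower number beyond the scatter; the furthest is compound 3, and the step of a 2.6-fold higher number from compound 2 to compound 3 (0.42 log units; beyond the scatter) is modest but also beyond the scatter.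

Compound 4 `NS(=O)(=O)c1cc(-c2nnc(CNC(=O)c3ccccc3)o2)c(Cl)cc1SCc1ccccc1` has not yet been measured. It differs from compound 2 in one place: benzamido in place of 4-carbamoyl-1H-1,2,3-triazol-1-yl on a saturated chain carbon bound to an aromatic carbon. The change sits on a saturated chain carbon bound to an aromatic carbon, on the arm that carries the variable group in all three measured compounds.

Going by the values given here, no measured step exchanges a triazole for an amide, so none bears on this change directly. Among the compounds with values here, the only step on the same arm, a 2.6-fold higher number from compound 2 to compound 3 (0.42 log units; beyond the scatter), shows that a change to the distal group moves the number by a modest amount. Compound 1, with a different group on the same arm, sits lower than compound 2, so either direction is open. Compound 4 is therefore expected to remain near compound 2, with an estimated step of a 1.3-fold lower number from compound 2 to compound 4 (0.12 log units; within the scatter) in this assay. The estimate for compound 4 is 55000 nM, with a range from 20000 nM to 160000 nM.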

Compound 4, half-maximal inhibitory concentration: 42000 nM
Compound 4: middle estimate off by 1.3-fold (0.12 log units), on the high side, and the stated range covers the measured number.
By their numbers in this assay, from the lowest: compounds 1, 4 and 2 (each within the scatter of the next, the first and the last beyond it); then compound 3.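

In this assay, replacing the whole 4-carbamoyl-1H-1,2,3-triazol-1-yl group with benzamido on this saturated chain carbon gives a step that stays within the scatter (a 1.7-fold lower number from compound 2 to compound 4 (0.23 log units; within the scatter)), even though a five-membered aromatic ring with three hetero atoms gives way to a six-membered aromatic ring of carbon only and the count of hydrogen-bond acceptors falls. Among the compounds shown, the triazole ring is therefore not needed for a number of this size, whereas the exchange on the triazole itself gave a step beyond the scatter (a 2.6-fold higher number from compound 2 to compound 3 (0.42 log units; beyond the scatter)), so a larger structural change at this position does not necessarily bring a larger step. No accompanying measurement offers an explanation for this result.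

The compounds shown leave open whether the amide hydrogen of the benzamido group matters, which a methyl group in its place could test, and whether a carboxylic acid on its benzene ring would move the number. They also leave open how a longer chain between the shared core and the benzamido group would read in this assay.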